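This account rests on a few compounds, and the source may have more. Where it says the series, first, only, none or still open, it means among the compounds named here.

Compound 2 `Cc1nn(-c2nc(-c3ccc(Cl)c(Cl)c3)c(SC(C)C)s2)c(C(=O)O)c1-c1ccccc1C(F)(F)F` gives 5200 nM in a functional assay on BJAB cells (Homo sapiens) for antiproliferative activity, with a stated time of 4 days (a lower number here means that less compound is needed, a higher number that more compound is needed for the effect), and stands lowest of the two numbers in this assay; its nearest neighbour is compound 1 `CC(=O)Nc1ccc(-c2c(C)nn(-c3nc(-c4ccc(Cl)c(Cl)c4)c(SC(C)C)s3)c2C(=O)O)cc1`, which gives 139000 nM. Among the compounds with values here, the one step recorded so far, a 27-fold lower number from compound 1 to compound 2 (1.43 log units; beyond the scatter), comes from exchanging the aryl group on the shared core, 2-(trifluoromethyl)phenyl in place of 4-acetamidophenyl on an aromatic carbon.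

Compound 3 `Cc1cc(Cl)cc(-c2c(C)nn(-c3nc(-c4ccc(Cl)c(Cl)c4)c(SC(C)C)s3)c2C(=O)O)c1` is not yet measured. It differs from compound 2 at the same place: 3-chloro-5-methylphenyl in place of 2-(trifluoromethyl)phenyl on an aromatic carbon. The step from compound 1 to compound 2 bears on this change in that it alters the same aryl group, and it was large; the group entering in compound 3, 3-chloro-5-methylphenyl, matches 2-(trifluoromethyl)phenyl in having no hydrogen-bond donors and no acceptors, so a swing as large as that step is not the expectation. A step in this assay of modest size, more likely toward a somewhat higher number, is expected for compound 3, a 1.7-fold higher number from compound 2 to compound 3 (0.24 log units; within the scatter). Compound 3 is estimated at 9000 nM, with a range from 2500 nM to 35000 nM.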

Compound 3, half-maximal effective concentration: 663 nM
For compound 3 the middle estimate is 14-fold (1.13 log units) above the measured one; the whole stated range lies above it.
By their numbers in this assay, from the lowest: compound 3; then compound 2; then compound 1.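

In this assay, the aryl group on the aromatic carbon next to the ring atom that bears a carboxy group still separates compounds when the hydrogen-bond counts do not change: 2-(trifluoromethyl)phenyl and 3-chloro-5-methylphenyl both count 0 hydrogen-bond donors and 0 hydrogen-bond acceptors, yet the exchange gives a 7.8-fold lower number from compound 2 to compound 3 (0.89 log units; beyond the scatter). The sensitivity of this position therefore extends beyond the loss of 4-acetamidophenyl, and across the three aryl groups the span reaches a 210-fold lower number from compound 1 to compound 3 (2.32 log units; beyond the scatter), with 3-chloro-5-methylphenyl giving the lowest number of the set. No measurement available here accounts for the difference between these two aryl groups.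

The compounds shown leave open whether the chlorine, the methyl or their combined placement carries the lower number, as 3-chloro-5-methylphenyl differs from 2-(trifluoromethyl)phenyl in all of these at once and no phenyl bearing only one of the two groups appears here. Also open, from the compounds shown here alone, is how an amine, a carboxylic acid or a longer alkyl chain on this aryl ring would read in this assay.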